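A Methoxy Added Ortho to a Hydroxy Group

The source may hold more compounds than are shown below. What is called first, only, known or untested is meant among the compounds shown, and "the series" means these compounds.

In a functional assay on CNE-2 cells (Homo sapiens) for antiproliferative activity, read by sulforhodamine B assay, with a stated time of 48 h (on this read-out lower numbers stand for stronger inhibition and higher numbers for weaker inhibition), compound 1 (`O=C(/C=C/c1ccccc1-c1ccc(F)cc1)c1cccc(O)c1`) gives 7300 nM and compound 2 (`O=C(/C=C/c1ccccc1-c1ccc(F)nc1)c1cccc(O)c1`) gives 8700 nM. Going by the values given here, compound 2 therefore stands level with compound 1, as the only measured step shows: a 1.2-fold higher number from compound 1 to compound 2 (0.08 log units; within the scatter). Compound 3 (`COc1ccc(C(=O)/C=C/c2ccccc2-c2ccc(F)nc2)cc1O`) keeps all of compound 2 but carries one addition, a methoxy in place of hydrogen on an aromatic carbon, ortho to a hydroxy group: methoxy in place of hydrogen on an aromatic carbon. Among the compounds with values here, the one measured step lies elsewhere in the molecule, so no measurement yet shows what a methoxy does here, and the size of any change stays uncertain. A moderate move towards a lower number is expected, and this is a cautious judgement with a wide margin: a 2.9-fold lower number from compound 2 to compound 3 (0.46 log units; beyond the scatter). Compound 3 is estimated at 3000 nM, with an expected range from 300 nM to 12000 nM.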

Compound 3, half-maximal inhibitory concentration: 2100 nM
Estimate against measurement, compound 3: 1.4-fold (0.15 log units) above, within the range that was stated.
By their numbers in this assay, from the lowest: compound 3; then compounds 1 and 2 (each within the scatter of the next).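

Placing a methoxy on this aromatic carbon, ortho to a hydroxy group and para to a large group, gives a 4.1-fold lower number from compound 2 to compound 3 (0.62 log units; beyond the scatter) in this assay. This is the only step shown that lies beyond the scatter, so the ring carrying the hydroxy group is a place where a small addition can change the number, while the earlier change on the fluorinated ring did not. Nothing measured on these compounds explains the shift, so the result stands as an observation without a known cause.

The compounds shown leave open whether an ethoxy or an amine on this same carbon would move the number as far as the methoxy does. They also leave open whether the methoxy would have the same effect without the hydroxy group ortho to it.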